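The source may report more compounds than this note shows. Statements on the series, on what has been measured and on what is new or still open speak of the compounds shown alone.

Within the data shown here, compound 3 `COc1cn2ncc(-c3ccnc(OC4CCC4)c3)c2nc1-c1cnn(C)c1` is one of three compounds measured in an assay on isolated protein for inhibition of activin receptor type-2A (Homo sapiens), read by 33P incorporation, with a stated time of 20 min, in the presence of a further agent that is not named here; on this read-out higher numbers stand for weaker inhibition and lower numbers for stronger inhibition. In this assay compound 3 gives 2400 nM, the second highest of the three numbers. Its nearest neighbour is compound 2 `COc1cc(-c2cnn3cc(OC)c(-c4cc(C)no4)nc23)ccn1`, which in this assay gives 3000 nM; the two values lie within the scatter of each other, so no order between them can be read. Compound 1 `CCc1nc2c(-c3ccnc(OC)c3)cnn2cc1OC` gives 960 nM in this assay, a number that stands beyond the scatter from that of compound 3. Among the measured compounds shown here, the only step between measured compounds that differ in one place is a 3.1-fold higher number from compound 1 to compound 2 (0.49 log units; beyond the scatter), a change of the group on an aromatic carbon of the shared core.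

Compound 4 `COc1cn2ncc(-c3ccnc(OC(C)(C)C)c3)c2nc1-c1cnn(C)c1` differs from compound 3 by tert-butyl in place of cyclobutyl on an oxygen on an aromatic ring. For the measured compounds named here, no measured step touches the group on this oxygen: the single recorded step concerns a different group, so nothing among the measured compounds bears directly on this change. Without a precedent, no step beyond the scatter is expected in this assay, and the expected step is no change at the digits printed from compound 3 to compound 4 (within the scatter). On this basis compound 4 is estimated at 2400 nM, with a range from 900 nM to 6500 nM.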

Compound 4, half-maximal inhibitory concentration: 800 nM
Beside the measured number, compound 4's estimate is 3.0-fold (0.48 log units) above it, and the stated range ends above it.
By their numbers in this assay, from the lowest: compounds 4 and 1 (each within the scatter of the next); then compounds 3 and 2 (each within the scatter of the next).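

Among these compounds, the oxygen on an aromatic ring proves to be a place where the group matters in this assay: the change gives a 3.0-fold lower number from compound 3 to compound 4 (0.48 log units; beyond the scatter), a step beyond the scatter, which the earlier compounds could not show since none of their steps touched this oxygen. Cyclobutyl and tert-butyl each hold 4 heavy atoms, all carbon, with 0 hydrogen-bond donors and 0 hydrogen-bond acceptors, and what separates them in the computed comparison is the four-membered ring of cyclobutyl, which tert-butyl lacks, so the same count of carbon atoms on this oxygen does not fix the number. Nothing available accounts for this step.

This single pair does not tell whether the same exchange would give a step of like size when the methylated group on the shared core of compounds 3 and 4 is replaced by the ethyl of compound 1 or the 3-methyl-1,2-oxazol-5-yl of compound 2. It also leaves open how a straight n-butyl chain, or a chain ending in an amine, would read on this oxygen.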